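Chloro for fluoro on the aryl amine of compound 2

A few compounds are considered here, and "the series" means these few. Any claim that something is new, unique, unknown or untested is made for them only; others in the source may bear on it.

Within the data shown here, compound 2 `Fc1ccc(Nc2ccc(N3CC4CC(C3)N4)nn2)cc1` gives 868 nM in an assay on cell membranes for displacement of a labelled ligand from Neuronal acetylcholine receptor; alpha4/beta2 (Rattus norvegicus) (a higher number here means a weaker inhibitor, a lower number a stronger inhibitor), the highest of the three numbers measured so far. Compound 1 `c1ccc(Nc2ccc(N3CC4CC(C3)N4)nn2)cc1` gives 441 nM; the step of a 2.0-fold higher number from compound 1 to compound 2 (0.29 log units; within the scatter) is within the scatter, so compounds 1 and 2 read as alike. Among the measured compounds shown here, compound 3 `Clc1cccc(Nc2ccc(N3CC4CC(C3)N4)cn2)c1` gives 2.2 nM, far from compound 2, but it differs from compound 2 in more than one place and no single-point step connects them.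

The unmeasured compound 4 `Clc1ccc(Nc2ccc(N3CC4CC(C3)N4)nn2)cc1` differs from compound 2 by chloro in place of fluoro on an aromatic carbon.

For the measured compounds named here, no measured step exchanges chloro for fluoro on the shared core. Going by the values given here, the only one-place step in the set, a 2.0-fold higher number from compound 1 to compound 2 (0.29 log units; within the scatter), concerns the same aromatic carbon and stays within the scatter. Compound 3 carries a chloro, yet on a different core and a different carbon, so its number is not carried over. For compound 4 the expected step of a 1.7-fold lower number from compound 2 to compound 4 (0.24 log units; within the scatter) is therefore small, with no direction claimed beyond the scatter. Compound 4 is estimated at 500 nM, range 150 nM to 1800 nM.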

Compound 4, inhibition constant: 90.4 nM
For compound 4 the middle estimate is 5.5-fold (0.74 log units) above the measured one; measured number below the stated range.
By their numbers in this assay, from the lowest: compound 3; then compound 4; then compounds 1 and 2 (each within the scatter of the next).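

The earlier step at this aromatic carbon, fluoro in place of hydrogen (a 2.0-fold higher number from compound 1 to compound 2 (0.29 log units; within the scatter)), left the position looking indifferent in this assay on the shared core. Chloro changes that reading: both chloro in place of fluoro (a 9.6-fold lower number from compound 2 to compound 4 (0.98 log units; beyond the scatter)) and chloro in place of hydrogen (a 4.9-fold lower number from compound 1 to compound 4 (0.69 log units; beyond the scatter)) lie beyond the scatter, so on this core the number depends on which atom sits on this carbon, with hydrogen and fluoro reading as alike and chloro standing apart. No evidence at hand bears on the reason for this difference.

Going by these compounds, whether bromo, methyl or methoxy on the same carbon would fall with chloro or with fluoro stays open. On these data alone, compound 3 also carries a chloro but differs from compound 4 in more than one place, so whether the chloro step holds on its core stays open too.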